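Swapping the Triazole Sulfanyl Group for a Pyrimidine

This account rests on a few compounds, and the source may have more. Where it says the series, first, only, none or still open, it means among the compounds named here.

Measured so far:
compound 1, `Cc1ccc(-c2cs/c(=N/NC(=O)CSc3nncn3C)n2-c2ccccc2)cc1`: 130 ug/mL
compound 2, `Cn1cnnc1SCC(=O)N/N=c1/scc(-c2ccc(Cl)cc2)n1-c1ccccc1`: 51.7 ug/mL

In an ADME assay on NIH3T3 cells (Mus musculus) for cytotoxicity, read by MTT assay, with a stated time of 24 h (on this read-out lower numbers stand for stronger inhibition and higher numbers for weaker inhibition), compound 1 gives the higher of the two numbers; compound 2 sits a 2.5-fold lower number from compound 1 to compound 2 (0.40 log units; beyond the scatter), a step at the aryl group that leaves the rest of the core untouched. Compound 3, `Cc1ccc(-c2cs/c(=N/NC(=O)CSc3ncccn3)n2-c2ccccc2)cc1`, differs from compound 1 in another place: pyrimidin-2-yl in place of 4-methyl-4H-1,2,4-triazol-3-yl on a sulfur. For the measured compounds named here, no measured step touches this sulfur-bound group, so the only guide is that the single step on record is modest. Compound 3 is therefore expected to stay near compound 1, a 1.2-fold lower number from compound 1 to compound 3 (0.07 log units; within the scatter), with the estimate for compound 3 being 110 ug/mL, in a range from 50 ug/mL to 250 ug/mL.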

Compound 3, half-maximal inhibitory concentration: > 500 ug/mL
Compound 3 gave a limit, no number; the forecaster's own chance of this, stated with the estimate: 10%; middle value at least 4.5-fold (0.65 log units) from the limit.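

The group on the sulfur proves to be a position that moves this read-out. In this assay, for the compounds shown here, pyrimidin-2-yl in place of 4-methyl-4H-1,2,4-triazol-3-yl gives an at least 3.8-fold higher number from compound 1 to compound 3 (0.58 log units; beyond the scatter), which means weaker inhibition, whereas the only earlier step, chloro in place of methyl, went towards stronger inhibition. Compound 3 has only a limit of the assay, not a number, and so the full size of this step stays unknown: the limit of > 500 ug/mL in this assay, at which 1 of the 3 values shown sits.

From the compounds shown here alone, it remains open whether other groups on this sulfur, such as a pyridin-2-yl ring or a plain methyl, would behave like pyrimidin-2-yl. Going by these compounds, it is also open whether chloro in place of methyl would lower the number with pyrimidin-2-yl on the sulfur.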